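Ester variants on the amide aryl ring

This account rests on a few compounds, and the source may have more. Where it says the series, first, only, none or still open, it means among the compounds named here.

Measured in an assay on cells for inhibition of Rho-associated protein kinase 2 (Homo sapiens), read by radiometric assay and 33P incorporation, in the presence of a further agent that is not named here; a higher number here means a weaker inhibitor, a lower number a stronger inhibitor:
Compound 1 `CCCOC(=O)c1cccc(C(=O)Nc2cccc(-c3cc(C(=O)Nc4ccncc4F)ccc3CN)c2)c1`: 1.8 nM
Compound 2 `COC(=O)c1cccc(NC(=O)c2cccc(-c3cc(C(=O)Nc4ccncc4F)ccc3CN)c2)c1F`: 1.2 nM
Compound 3 `NCc1ccc(C(=O)Nc2ccncc2F)cc1-c1cccc(C(=O)Nc2cccc(C(=O)O)c2F)c1`: 3.5 nM

Compound 1 stands second highest of the three numbers; its nearest neighbour is compound 2, and the gap to compound 3 is also within the scatter, so the three sit close together.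

Compound 4 `COC(=O)c1ccc(F)c(C(=O)Nc2cccc(-c3cc(C(=O)Nc4ccncc4F)ccc3CN)c2)c1` is not yet measured. Relative to compound 1 the change is 2-fluoro-5-(methoxycarbonyl)phenyl in place of 3-(propoxycarbonyl)phenyl on a carbonyl carbon. Among the compounds with values here, the only step with a number is a 2.9-fold higher number from compound 2 to compound 3 (0.46 log units; beyond the scatter), a modest change on going from an ester to a free acid; compound 4 keeps an ester, so that step does not bear directly on the move from compound 1 to compound 4. Compound 1 and compound 2, which differ in the ester and in a fluorine, give values within the scatter of each other. Compound 4 is therefore expected to stay in the same range, with a 1.1-fold lower number from compound 1 to compound 4 (0.05 log units; within the scatter) nothing beyond the scatter. The estimate for compound 4 in this assay is 1.6 nM, expected between 0.6 nM and 4.5 nM.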

Compound 4, half-maximal inhibitory concentration: < 1 nM
Compound 4 was reported as a limit (the forecaster's own chance of this, stated with the estimate: 2%); middle value at least 1.6-fold (0.20 log units) from the limit.
By their numbers in this assay, from the lowest: compounds 2, 1 and 3 (each within the scatter of the next, the first and the last beyond it). At a limit, below all of these: compound 4.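

In this assay, within the data shown here, compound 4 gives < 1 nM as a limit of the assay, not a number, and the series touches that limit for the first time here: the limit of < 1 nM in this assay, at which 1 of the 4 values shown sits. The step reads an at least 1.8-fold lower number from compound 1 to compound 4 (0.25 log units; that floor lies within the scatter) for 2-fluoro-5-(methoxycarbonyl)phenyl in place of 3-(propoxycarbonyl)phenyl on a carbonyl carbon, so only a floor for its size is known. Among these compounds, the new information is that this position takes the fluorine and the methyl ester together with no loss of inhibition, a change that the earlier compounds did not cover.

The fluorine and the shorter ester chain enter in one step, so their separate shares remain unresolved. Also open, as far as these compounds go, is how a carboxylic acid, an amine or a longer chain in place of the ester on this ring would read.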